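Ethyl to ethoxy on an imidazoline ether core

A few compounds are considered here, and "the series" means these few. Any claim that something is new, unique, unknown or untested is made for them only; others in the source may bear on it.

Measured compounds:
compound 1, `Cc1cccc(C)c1OC(C)C1=NCCN1`: 0.8
compound 2, `CC(Oc1ccccc1Br)C1=NCCN1`: 0.4
compound 3, `CCc1ccccc1OC(C)C1=NCCN1`: 0.5

Of the compounds shown here, three sharing one core have been measured in an assay on CHO cells with Alpha-2B adrenergic receptor (Homo sapiens) as the target; on this read-out lower numbers stand for smaller maximal responses and higher numbers for larger maximal responses. Among these three numbers compound 3 stands second highest. Its nearest neighbour is compound 2, whose value lies within the usual scatter of that of compound 3, so the two cannot be told apart. Compound 1 is the furthest away, giving a number beyond the scatter higher than compound 3.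

Compound 4, `CCOc1ccccc1OC(C)C1=NCCN1`, has not yet been measured. It differs from compound 3 in one place: ethoxy in place of ethyl on an aromatic carbon. For the measured compounds named here, the only measured step that changes a group on that same aromatic carbon is a number 0.10 higher from compound 2 to compound 3 (within the scatter), a swap of bromo for ethyl that stayed within the scatter. Going by the values given here, no measured step replaces ethyl by ethoxy, so nothing here points to a shift beyond the scatter in either direction. Compound 4 is therefore expected to show a step of no change at the digits printed from compound 3 to compound 4 (within the scatter) in this assay. The estimated value for compound 4 is 0.5, with a range from 0.3 to 0.7.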

Compound 4, intrinsic activity: the largest response reached, as a fraction of the reference agonist's: 0.5
Compound 4: the middle estimate sits on the measured number at the digits printed; the measured number falls inside the stated range.
By their numbers in this assay, from the lowest: compounds 2, 3 and 4 (each within the scatter of the next); then compound 1.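

In this assay, ethoxy in place of ethyl adds an oxygen to the group on this aromatic carbon, and the outcome is no change at the digits printed from compound 3 to compound 4 (within the scatter) for this swap. For the compounds shown here, the earlier compounds had only compared bromo with ethyl, so this is the first look at a group carrying a hydrogen-bond acceptor here, and that acceptor brings no difference that can be told from the scatter. Ethoxy measured against bromo gives a number 0.10 higher from compound 2 to compound 4 (within the scatter) as well, so all three groups on this carbon, bromo, ethyl and ethoxy, now read alike within the scatter.

As far as these compounds go, it remains open whether a group of another kind at this place, such as an amine, a carboxylic acid or a longer chain like butoxy, would give a step beyond the scatter. Nothing shown here explains why these three groups read alike.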